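A few compounds are considered here, and "the series" means these few. Any claim that something is new, unique, unknown or untested is made for them only; others in the source may bear on it.

Compound 1 `COC1=C(OC)[C@H](O)[C@H](C/C=C(\C)CC/C=C(\C)C[C@H](O)/C=C(\C)CO)[C@@H](C)C1=O` and compound 2 `COC1=C(OC)[C@H](OC(C)=O)[C@H](C/C=C(\C)CC/C=C(\C)C[C@H](O)C=C(C)C)[C@@H](C)C1=O` share one core and were both tested in a functional assay on PC-3 cells (Homo sapiens) for inhibition, read by sulforhodamine B assay, with a stated time of 48 h; a lower number here means a stronger inhibitor of growth, a higher number a weaker inhibitor of growth. In this assay compound 1 reaches only a limit, > 30000 nM. Compound 2 likewise gives only a limit, > 30000 nM. Within the data shown here, the one thing the numbers establish is the limit of > 30000 nM in this assay, at which 2 of the 2 values shown sit. Compound 3 `COC1=C(OC)[C@H](OC(C)=O)[C@H](C/C=C(\C)CC/C=C(\C)C[C@H](O)/C=C(\C)CO)[C@@H](C)C1=O` differs from compound 2 by hydroxy in place of hydrogen on a saturated chain carbon bound to a double-bonded chain carbon. Among the measured compounds shown here, no measured step covers this change, and the two values rest on the same limit, so no direction can be read from them. Compound 3 is therefore expected to move little, an estimated step that the limit leaves unreadable from compound 2 to compound 3. Compound 3 is estimated at 40000 nM, with a range from 15000 nM to 100000 nM.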

Compound 3, concentration for 50% growth inhibition: > 30000 nM
Compound 3 ended at the assay's limit (the forecaster's own chance of this, stated with the estimate: 75%); the middle value does not contradict the limit.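

Among these compounds, no step from compound 1 or compound 2 to compound 3 can be read in this assay, as all three values are limits: the limit of > 30000 nM in this assay, at which 3 of the 3 values shown sit.
The compounds shown leave open whether the hydroxy or acetyl change alters growth inhibition at all.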